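A few compounds are considered here, and "the series" means these few. Any claim that something is new, unique, unknown or untested is made for them only; others in the source may bear on it.

Compound 1, `O=C(Nc1cc(-c2ccccc2)nn1-c1ccccc1)c1ccc(F)cc1`, gives 30 nM in an assay on CHO cells with metabotropic glutamate receptor 5 (Homo sapiens) as the target; a higher number here means that more compound is needed for the effect, a lower number that less compound is needed.
Compound 2, `O=C(Nc1cc(-c2ccccc2)nn1-c1ccccc1)c1ccccc1`, gives 40 nM.
Compound 3, `O=C(Nc1cc(-c2ccccc2)nn1-c1ccccc1)c1ccccn1`, gives 290 nM.

Within this set, compound 3 gives the highest number, so the most compound is needed for the effect. Both steps that lead to it, a 9.7-fold higher number from compound 1 to compound 3 (0.99 log units; beyond the scatter) and a 7.3-fold higher number from compound 2 to compound 3 (0.86 log units; beyond the scatter), replace a ring of carbon only on the carbonyl carbon with the pyridin-2-yl ring, and both lie beyond the scatter. The step of a 1.3-fold higher number from compound 1 to compound 2 (0.12 log units; within the scatter) lies within the scatter, so the fluoro hardly matters here.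

Compound 4, `O=C(Nc1cc(-c2ccccc2)nn1-c1ccccc1)c1ccccc1O`, has not yet been measured. Its change from compound 3 is 2-hydroxyphenyl in place of pyridin-2-yl on a carbonyl carbon. Among the measured compounds shown here, this puts a ring of carbon only back on the carbonyl carbon, as in compound 2, now carrying a hydroxy group that no measured compound has. The two steps toward compound 3 bear on this change in reverse, so a lower number is expected in this assay, with a size near a 4.8-fold lower number from compound 3 to compound 4 (0.68 log units; beyond the scatter). From the compounds shown here alone, the estimate for compound 4 is 60 nM, with a range from 20 nM to 200 nM; the hydroxy group is untested, so the range is kept wide.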

Compound 4, half-maximal effective concentration: > 10000 nM
Compound 4 ended at the assay's limit (the forecaster's own chance of this, stated with the estimate: 5%); at least 160-fold (2.22 log units) between middle value and limit.
By their numbers in this assay, from the lowest: compounds 1 and 2 (each within the scatter of the next); then compound 3. At a limit, above all of these: compound 4.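

Compound 4 gives > 10000 nM in this assay, which is a limit of the assay and not a number: the limit of > 10000 nM in this assay, at which 1 of the 4 values shown sits.

Adding one hydroxy group to the phenyl ring on the carbonyl carbon gives an at least 250-fold higher number from compound 2 to compound 4 (2.39 log units; beyond the scatter), so this position, where swapping fluoro for hydrogen stayed within the scatter, can respond very strongly to a small change. The 2-hydroxyphenyl group also compares poorly with the other two rings, with an at least 34-fold higher number from compound 3 to compound 4 (1.53 log units; beyond the scatter) and an at least 330-fold higher number from compound 1 to compound 4 (2.52 log units; beyond the scatter), so it sits beyond even pyridin-2-yl, previously the ring with the highest number.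

The compounds shown do not tell whether a methoxy group or an amine in place of the hydroxy group would give a similar result. Among the compounds shown here, compound 4 is also the only one carrying a hydroxy group, so it remains open how general this effect is.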